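Plasma half-life of the bis-ester series: compound 4 outlook

The source may report more compounds than this note shows. Statements on the series, on what has been measured and on what is new or still open speak of the compounds shown alone.

Measured compounds and values in an ADME assay on a cell-free system (plasma, Homo sapiens) for metabolic stability, with Plasma (Rattus norvegicus) as the target, read by HPLC, at pH 7.4; on this read-out higher numbers stand for a longer-lived compound and lower numbers for a shorter-lived compound:
compound 1 `CC(=O)Oc1ccccc1C(=O)O[C@H]1CO[C@H]2[C@@H]1OC[C@H]2OC(=O)C1CC1`: 0.015 h
compound 2 `CC(=O)Oc1ccccc1C(=O)O[C@H]1CO[C@H]2[C@@H]1OC[C@H]2OC(=O)c1ccccc1C`: 0.0138 h
compound 3 `COc1ccccc1C(=O)O[C@@H]1CO[C@H]2[C@@H]1OC[C@@H]2OC(=O)c1ccccc1OC(C)=O`: 0.0165 h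

All three share the same core and the same acetylsalicyloyl ester; they differ only in the second ester group on a carbonyl carbon. Compound 3 sits together with compound 1 and compound 2: the step of a 1.1-fold higher number from compound 1 to compound 3 (0.04 log units; within the scatter) and the step of a 1.2-fold higher number from compound 2 to compound 3 (0.08 log units; within the scatter) are both within the scatter, as is a 1.1-fold lower number from compound 1 to compound 2 (0.04 log units; within the scatter). Nothing among these three numbers separates a cyclopropyl, a 2-methylphenyl or a 2-methoxyphenyl at this position.

Compound 4 `CC(=O)Oc1ccccc1C(=O)O[C@H]1CO[C@H]2[C@@H]1OC[C@H]2OC(=O)c1cnccc1Cl` is not yet measured. The change from compound 3 is 4-chloropyridin-3-yl in place of 2-methoxyphenyl on a carbonyl carbon. Going by the values given here, no measured step replaces a carbon ring with a ring holding a nitrogen and a chlorine at this position, so the bearing steps are only the three above, all within the scatter. On that basis no step beyond the scatter is expected: a 1.1-fold lower number from compound 3 to compound 4 (0.04 log units; within the scatter). For compound 4 in this assay the estimate is 0.015 h, with a range from 0.008 h to 0.03 h.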

Compound 4, half-life: 0.0322 h
Compound 4: the middle estimate sits 2.1-fold (0.33 log units) below what was measured; the whole stated range lies below it.
By their numbers in this assay, from the lowest: compounds 2, 1, 3 and 4 (each within the scatter of the next, the first and the last beyond it).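

In this assay, this position on a carbonyl carbon gives its first separation beyond the scatter: 4-chloropyridin-3-yl shows a 2.1-fold higher number from compound 1 to compound 4 (0.33 log units; beyond the scatter) against cyclopropyl and a 2.3-fold higher number from compound 2 to compound 4 (0.37 log units; beyond the scatter) against 2-methylphenyl, both modest. Against 2-methoxyphenyl the same change shows a 2.0-fold higher number from compound 3 to compound 4 (0.29 log units; within the scatter), so the separation holds for only two of the three earlier groups. No evidence at hand bears on what lies behind these steps.

Open, going by these compounds, is whether the ring nitrogen or the chlorine goes with the higher half-life, since a plain pyridin-3-yl or a 2-chlorophenyl at this position would be needed to tell them apart. Also open, on these data alone, is how an amine or a carboxylic acid on the ring, or a longer chain in its place, would read.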